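The compounds below may be only part of what the source reports. "The series", "measured", "known", "first", "only" and "open" are said of these compounds alone.

Of the compounds shown here, three sharing one core have been tested so far in an ADME assay on HFF cells (Homo sapiens) for cytotoxicity, with a stated time of 8 days (on this read-out higher numbers stand for lower toxicity in this test and lower numbers for higher toxicity in this test), as a measure of cell toxicity. Compound 1 `CNc1nc(N)nc2c1ncn2/C=C1/CC1(CO)CO` gives 265000 nM in this test. Compound 2 `Nc1nc(NC2CCCC2)c2ncn(/C=C3/CC3(CO)CO)c2n1` gives > 300000 nM as a limit of the assay and not a number. Compound 3 `CSc1nc(N)nc2c1ncn2/C=C1/CC1(CO)CO` gives > 300000 nM as a limit too. Compound 3 thus stands at the limit of > 300000 nM in this assay, at which 2 of the 3 values shown sit, and has no exact number of its own.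

Compound 4 `CCCCCCSc1nc(N)nc2c1ncn2/C=C1/CC1(CO)CO` differs from it in one place: pentyl in place of hydrogen on a saturated chain carbon bound to a sulfur is the change, pentyl in place of hydrogen on a saturated chain carbon bound to a sulfur, which turns methylsulfanyl into hexylsulfanyl. For the measured compounds named here, two measured steps bear on this. Bringing in methylsulfanyl gave an at least 1.1-fold higher number from compound 1 to compound 3 (0.05 log units; that floor lies within the scatter) and is the closest comparison, while cyclopentyl in place of methyl gave an at least 1.1-fold higher number from compound 1 to compound 2 (0.05 log units; that floor lies within the scatter) as its result. Neither step shows a fall in the number. No chain as long as hexyl has been tested, however, so a modest fall cannot be ruled out. The expected change is small and downward, an at least 1.6-fold lower number from compound 3 to compound 4 (0.22 log units; that floor lies within the scatter) by estimate. For compound 4 the expected value is 180000 nM with an estimated range running from 60000 nM to 300000 nM on this read-out.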

Compound 4, half-maximal cytotoxic concentration: > 300000 nM
Compound 4 gave a limit, no number; the forecaster's own chance of this, stated with the estimate: 35%; middle value at least 1.6-fold (0.22 log units) away from the limit.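

Going from methylsulfanyl to hexylsulfanyl puts pentyl in place of hydrogen on a saturated chain carbon bound to a sulfur, and this assay still shows no fall in the number, so this position accepts a far longer chain than the earlier compounds had shown. Hexylsulfanyl in place of methylamino gave an at least 1.1-fold higher number from compound 1 to compound 4 (0.05 log units; that floor lies within the scatter), so this comparison with the one compound that has an exact number shows no fall either, though its floor is too small to show a rise. The steps from compound 3 and from compound 2 to compound 4 cannot be read, and the upper end of the test now holds most of the series: the limit of > 300000 nM in this assay, at which 3 of the 4 values shown sit.

Going by these compounds, compound 2, compound 3 and compound 4 therefore cannot be ranked against one another, and it stays open whether any change at this sulfur would bring the number down. A longer chain such as decyl, or a hexyl chain ending in an amine or a carboxylic acid, could show whether the number ever drops to a value that can be read.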